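The compounds below may be only part of what the source reports. "The series", "measured", "known", "first", "only" and "open" are said of these compounds alone.

In a functional assay on MDA-MB-231 cells (Homo sapiens) for cytotoxicity, read by MTT assay, with a stated time of 38 h (on this read-out lower numbers stand for stronger inhibition and higher numbers for weaker inhibition), compound 3 `COc1cc(OC)c2c(=O)c(OCC(=O)N/N=C/c3ccc[nH]3)c(-c3cc(OC)c(OC)c(OC)c3)oc2c1` gives 3750 nM and so lies within the scatter of compound 1 `COc1cc(OC)c2c(=O)c(OCC(=O)N/N=C/c3ccccc3F)c(-c3cc(OC)c(OC)c(OC)c3)oc2c1` with 3400 nM as its value, while compound 2 `COc1cc(OC)c2c(=O)c(OCCCN3CCN(C)CC3)c(-c3cc(OC)c(OC)c(OC)c3)oc2c1` stands apart from both with 30100 nM as its value. Compound 4 `COc1cc(OC)c2c(=O)c(OCC(=O)N/N=C/c3ccco3)c(-c3cc(OC)c(OC)c(OC)c3)oc2c1` differs from compound 3 by furan-2-yl in place of 1H-pyrrol-2-yl on a carbon with a double bond to nitrogen in one exchange, furan-2-yl in place of 1H-pyrrol-2-yl on a carbon with a double bond to nitrogen. The nearest guide is a 1.1-fold higher number from compound 1 to compound 3 (0.04 log units; within the scatter) for 1H-pyrrol-2-yl in place of 2-fluorophenyl at that same place, a step within the scatter. The larger steps of an 8.9-fold higher number from compound 1 to compound 2 (0.95 log units; beyond the scatter) and an 8.0-fold lower number from compound 2 to compound 3 (0.90 log units; beyond the scatter) both change the whole group on the saturated chain carbon bound to an oxygen on an aromatic ring, and they bear little on this exchange. For the measured compounds named here, no measured compound carries furan-2-yl, so the guide is thin. In this assay the expected step is a 1.0-fold lower number from compound 3 to compound 4 (0.02 log units; within the scatter) and nothing beyond the scatter is expected. The estimate for compound 4 is 3600 nM with an expected range of 1700 nM to 7500 nM in this read-out.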

Compound 4, half-maximal inhibitory concentration: 1860 nM
The estimate for compound 4 lay 1.9-fold (0.29 log units) above the measured number; measured number inside the range.
By their numbers in this assay, from the lowest: compounds 4, 1 and 3 (each within the scatter of the next); then compound 2.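

In this assay, furan-2-yl on a carbon with a double bond to nitrogen gives a 2.0-fold lower number from compound 3 to compound 4 (0.30 log units; within the scatter) and a 1.8-fold lower number from compound 1 to compound 4 (0.26 log units; within the scatter) and so stays within the scatter of both 1H-pyrrol-2-yl and 2-fluorophenyl at this place, even though the exchange for 1H-pyrrol-2-yl swaps the ring nitrogen for an oxygen and removes the hydrogen-bond donor. The one clear gap still lies with the whole group on the saturated chain carbon bound to an oxygen on an aromatic ring, where a 16-fold lower number from compound 2 to compound 4 (1.21 log units; beyond the scatter) is a large step, larger than either step from compound 2 seen before. No measurement at hand offers a reason for these results.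

The compounds shown leave open whether a pyridine ring or a carboxylic acid at this place would also stay within the scatter. They also leave open how much of the gap to compound 2 belongs to its piperazine ring and how much to the chain that carries it.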